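Fluoro in place of trifluoromethyl on two different cores

A few compounds are considered here, and "the series" means these few. Any claim that something is new, unique, unknown or untested is made for them only; others in the source may bear on it.

Compound 1 `C=C1C[C@]23C[C@@]1(O)CC[C@H]2c1ccc(O)c(C)c1[C@@H]3Cn1cc(-c2ccc(C(F)(F)F)cc2)nn1` and compound 2 `C=C1C[C@]23C[C@@]1(O)CC[C@H]2c1ccc(O)c(C)c1[C@@H]3Cn1cc(-c2ccc(F)cc2)nn1` share one core, while compound 3 `Cc1ccc(S(=O)(=O)Oc2ccc3c(c2C)[C@H](Cn2cc(-c4ccc(C(F)(F)F)cc4)nn2)[C@@]24CC(=O)[C@@](C)(CC[C@@H]32)C4)cc1` and compound 4 `Cc1ccc(S(=O)(=O)Oc2ccc3c(c2C)[C@H](Cn2cc(-c4ccc(F)cc4)nn2)[C@@]24CC(=O)[C@@](C)(CC[C@@H]32)C4)cc1` share another; the difference between the two cores is not broken down here. In a functional assay on A549 cells (Homo sapiens) for cytotoxicity, read by MTT assay, with a stated time of 4 days (a lower number here means a stronger inhibitor, a higher number a weaker inhibitor), compound 1 gives 10400 nM. Compound 2 reaches only the limit of this assay, > 20000 nM. That step, an at least 1.9-fold higher number from compound 1 to compound 2 (0.28 log units; that floor lies within the scatter), goes with fluoro in place of trifluoromethyl on an aromatic carbon. Compound 3 also sits at the limit of this assay, > 20000 nM, in keeping with the limit of > 20000 nM in this assay, at which 2 of the 3 values shown sit. Compound 4 carries the same change, (fluoro in place of trifluoromethyl on an aromatic carbon). Since the earlier step of an at least 1.9-fold higher number from compound 1 to compound 2 (0.28 log units; that floor lies within the scatter) already weakened the compound, compound 4 is expected to remain at the limit, with an estimated step that the limit leaves unreadable from compound 3 to compound 4 and an expected value of 35000 nM.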

Compound 4, half-maximal inhibitory concentration: > 20000 nM
Compound 4 gave a limit, no number; the forecaster's own chance of this, stated with the estimate: 90%; the middle value does not contradict the limit.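

Compound 3 and compound 4 both stop at a limit of the assay rather than a number, so no step can be read between them: the limit of > 20000 nM in this assay, at which 3 of the 4 values shown sit.

The compounds shown leave open how fluoro in place of trifluoromethyl acts on this core in this assay.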